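The compounds below may be only part of what the source reports. "The series", "measured", "known", "first", "only" and "open" are said of these compounds alone.

Compound 1 `CC(C)C(=O)N(Cc1ccccc1C(F)(F)F)[C@H]1CCNC1` carries an isopropylcarbonyl on the amine nitrogen of the shared core; in an assay on HEK293 cells for inhibition of sodium-dependent dopamine transporter (Homo sapiens) (a lower number here means a stronger inhibitor, a higher number a weaker inhibitor), compound 1 stands at "not determined" (no result reported), as no result was reported for it. Two relatives built on the same core were measured: compound 2 `CCOC(=O)N(Cc1ccccc1C(C)C)[C@H]1CCNC1` gives 3340 nM in this assay, and compound 3 `CN(C)C(=O)N(Cc1ccccc1-c1ccccc1)[C@H]1CCNC1` gives 2970 nM, two values that sit close together. Compound 4 `CS(=O)(=O)N(Cc1ccccc1C(F)(F)F)[C@H]1CCNC1` differs from compound 1 by methylsulfonyl in place of isopropylcarbonyl on an amine nitrogen. Going by the values given here, no step between measured compounds covers this change, so compound 1 offers no anchor for its direction, and in this assay no shift beyond the usual scatter is expected from it. Judged from compounds 2 and 3, compound 4 is expected to land near 3200 nM, within a range of 900 nM to 12000 nM.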

Compound 4, inhibition constant: 2890 nM
Beside the measured number, compound 4's estimate is 1.1-fold (0.04 log units) above it, within the range that was stated.
By their numbers in this assay, from the lowest: compounds 4, 3 and 2 (each within the scatter of the next).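

Going by these compounds alone, compound 4 and compound 1 yield no step that can be read, as compound 1 stands at "not determined" (no result reported). The shown compounds leave open what replacing isopropylcarbonyl with methylsulfonyl does in this assay. No evidence bears on this result.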